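The compounds below may be only part of what the source reports. "The series", "measured", "known", "first", "only" and "open" are said of these compounds alone.

Working notes on the series. Compound 1 `COC(C)(C)CCCC(C)C/C=C/C(C)=C/C(=O)OCCC(C)C` gives 7.03 in a physicochemical assay for lipophilicity (a higher number here means a more lipophilic compound, a lower number a more polar compound), the second highest of the three numbers in hand. Compound 2 `CCOC(C)(C)CCCC(C)C/C=C/C(C)=C/C(=O)OC(C)C` reads 6.49, a step down from compound 1 that lies beyond the scatter. Compound 3 `CCSC(=O)/C=C(C)/C=C/CC(C)CCCC(C)C` reads 7.98, the highest number here and beyond the scatter above compound 1. Among the compounds with values here, no single-point steps between measured compounds are available, so the next step rests on the structural change alone. Compound 4 `COC(C)(C)CCCC(C)C/C=C/C(C)=C/C(=O)N(C)C` differs from compound 1 in one place: dimethylamino in place of isopentyloxy on a carbonyl carbon. A large drop in this assay, well beyond the scatter, is expected from compound 1 to compound 4, estimated at a number 2.73 log units lower from compound 1 to compound 4 (beyond the scatter). Compound 4 is therefore estimated at 4.3, within a range from 3.6 to 5.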

Compound 4, partition coefficient: 3.74
Beside the measured number, compound 4's estimate is 0.56 log units above it, within the range that was stated.
By their numbers in this assay, from the lowest: compound 4; then compound 2; then compound 1; then compound 3.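

Dimethylamino in place of isopentyloxy on a carbonyl carbon gives a number 3.29 log units lower from compound 1 to compound 4 (beyond the scatter) in this assay. Within the data shown here, this is the first reading of a change in one place, and it shows that the group held on this carbonyl carbon can move the number by a large amount. Nothing measured here speaks to the cause of the step.

This one pair also leaves the nitrogen-for-oxygen exchange tied to the change in group size. On the same carbonyl carbon, a methoxy group or a longer dialkylamino group such as dipentylamino would begin to separate the two.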